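Trading Dimethylamino for Hydrogen on the Shared Core

The source may hold more compounds than are shown below. What is called first, only, known or untested is meant among the compounds shown, and "the series" means these compounds.

Compound 1 `[N-]=[N+]=Nc1nccc2c1ncn2[C@H]1C[C@H](O)[C@@H](CO)O1` gives 13% in a functional assay on EL4 cells (Mus musculus) for inhibition, tested at 100 uM; a higher number here means more inhibition at the concentration tested (going by the name of the read-out), a lower number less inhibition. Compound 2 `CN(C)c1nccc2c1ncn2[C@H]1C[C@H](O)[C@@H](CO)O1` reaches only a limit of this assay, < 5%. The change a number at least 8 percentage points lower from compound 1 to compound 2 (that floor lies within the scatter) is therefore bounded below by the limit (the limit of < 5% in this assay, at which 1 of the 3 values shown sits). Compound 3 `OC[C@H]1O[C@@H](n2cnc3cnccc32)[C@H](O)[C@@H]1O`, which carries no dimethylamino group, likewise shows only a limit of this assay, < 5%; < 5% (2 entries), in both of its entries. So compound 2 stands at the lower limit, with no single number to its name.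

Compound 4 `OC[C@H]1O[C@@H](n2cnc3cnccc32)C[C@@H]1O` differs from compound 2 by hydrogen in place of dimethylamino on an aromatic carbon. Among the measured compounds shown here, the one measured step, from compound 1 to compound 2, concerns the same aromatic carbon but a different exchange, and it ends at the limit; compound 3, also without the dimethylamino group, sits at the same limit. For the measured compounds named here, no measured step therefore points upward, and compound 4 is expected to show a step that the limit leaves unreadable from compound 2 to compound 4 of no size beyond the scatter. Compound 4 is accordingly estimated at 4%, within 0% to 12%.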

Compound 4, a percentage reported as inhibition, at one concentration (the size of the read-out at that concentration, not a potency): < 5%
Compound 4: only a limit was reported; the forecaster's own chance of this, stated with the estimate: 60%; the middle value does not contradict the limit.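

With hydrogen on this aromatic carbon, next to the ring nitrogen, compound 4 also reaches only a limit in this assay, < 5%. The azido group of compound 1 can now be compared with a second replacement, and exchanging it for hydrogen gives a number at least 8 percentage points lower from compound 1 to compound 4 (that floor lies within the scatter). The step between dimethylamino and hydrogen cannot be read, so the two groups cannot be told apart at this position, as both ends of that step are limits: the limit of < 5% in this assay, at which 2 of the 4 values shown sit.

On these data alone, it remains open whether the azido group truly stands apart from hydrogen and dimethylamino, given that the floor of its step lies within the scatter. As far as these compounds go, how an amine, a methoxy group or a longer chain on this aromatic carbon would read in this assay also stays open.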